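This account rests on a few compounds, and the source may have more. Where it says the series, first, only, none or still open, it means among the compounds named here.

Measured compounds in an in vitro functional assay on cells for antagonist activity at metabotropic glutamate receptor 1 (Rattus norvegicus), read by inositol phosphate accumulation; a higher number here means a weaker inhibitor, a lower number a stronger inhibitor: compound 1 `CC1(C)CC(=O)c2cc(C#N)c(NC3CCCCC3)nc2C1` gives 4000 nM; compound 2 `CC1(C)CC(=O)c2cc(C#N)c(N3CCN(c4ccc(F)cc4)CC3)nc2C1` gives 160 nM; compound 3 `CC1(C)CC(=O)c2cc(Br)c(N3CCN(c4ccc(F)cc4)CC3)nc2C1` is reported only as a limit, <= 1000 nM.

Compound 1 stands highest of the two numbers in this assay, with compound 2 well below it and beyond the scatter. The value of compound 3 is the limit of <= 1000 nM in this assay, at which 1 of the 3 values shown sits, so the step that the limit leaves unreadable from compound 2 to compound 3 cannot be read in size. Compound 4 `CC1(C)CC(=O)c2cc(C#N)c(NCc3ccccc3)nc2C1` differs from compound 1 by benzyl in place of cyclohexyl on a nitrogen on an aromatic ring. Going by the values given here, no measured step touches this nitrogen substituent directly; the distance from compound 1 to compound 2 shows only that this part of the core matters. Compound 4 is therefore expected to stay near compound 1, with a 1.3-fold lower number from compound 1 to compound 4 (0.12 log units; within the scatter) not beyond the scatter. Compound 4 is estimated at 3000 nM, between 800 nM and 12000 nM.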

Compound 4, half-maximal inhibitory concentration: 2500 nM
Estimate against measurement, compound 4: 1.2-fold (0.08 log units) above; the measured number falls inside the stated range.
By their numbers in this assay, from the lowest: compound 2; then compounds 4 and 1 (each within the scatter of the next).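

On a nitrogen on an aromatic ring, benzyl in place of cyclohexyl gives a 1.6-fold lower number from compound 1 to compound 4 (0.20 log units; within the scatter) in this assay. At this position, then, exchanging a six-membered non-aromatic ring of carbon only for a benzyl group with its aromatic ring does not separate the two compounds. No measured property shown bears on this result.

On these data alone, it remains open whether phenethyl, a longer chain, or pyridylmethyl on this nitrogen would read differently from compound 1 and compound 4. As far as these compounds go, the effect of a carboxylic acid or an amine on the benzyl group also remains open.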